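The source may hold more compounds than are shown below. What is called first, only, known or untested is meant among the compounds shown, and "the series" means these compounds.

Within the data shown here, compound 1 `O=C(COc1ccc2cc(C(O)(C(F)(F)F)C(F)(F)F)c(O)cc2c1)Nc1nc2ccccc2s1` is the one member of this small set for which an assay on isolated protein for inhibition of tyrosine-protein phosphatase non-receptor type 13 (Homo sapiens), read by spectrophotometry (on this read-out higher numbers stand for weaker inhibition and lower numbers for stronger inhibition), returns a number: compound 1 gives 9900 nM. Compound 2 `O=C(COc1ccc2cc(C(O)(C(F)(F)F)C(F)(F)F)c(O)cc2c1)Nc1ccccc1` carries a phenyl on the amide-type nitrogen, and in this assay compound 2 gives only the limit > 20000 nM. Compound 3 `O=C(COc1ccc2cc(C(O)(C(F)(F)F)C(F)(F)F)c(O)cc2c1)NCc1ccccc1` carries a benzyl there, and in this assay compound 3 likewise gives only the limit > 20000 nM. The two measured steps are therefore floors: an at least 2.0-fold higher number from compound 1 to compound 2 (0.30 log units; that floor lies within the scatter) and an at least 2.0-fold higher number from compound 1 to compound 3 (0.30 log units; that floor lies within the scatter), both read against (the limit of > 20000 nM in this assay, at which 2 of the 3 values shown sit). The step from compound 2 to compound 3 is a step that the two limits leave unreadable from compound 2 to compound 3.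

Compound 4 `O=C(COc1ccc2cc(C(O)(C(F)(F)F)C(F)(F)F)c(O)cc2c1)Nc1ccc(-c2ccccc2)cc1` differs from compound 1 by 4-phenylphenyl in place of 1,3-benzothiazol-2-yl on an amide-type nitrogen. The steps from compound 1 to compound 2 and to compound 3 bear on it, since both swap the 1,3-benzothiazol-2-yl for a carbon-only aryl and both reach the limit. Compound 4 is expected to move toward those floors rather than far past them, an estimated 1.8-fold higher number from compound 1 to compound 4 (0.26 log units; within the scatter). Compound 4 is thus estimated at 18000 nM, in the range from 6000 nM to 50000 nM.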

Compound 4, half-maximal inhibitory concentration: 2800 nM
For compound 4 the middle estimate is 6.4-fold (0.81 log units) above the measured one; the whole stated range lies above it.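

In this assay, the amide-type nitrogen now proves able to carry a group of carbon only and still give a stronger result than the 1,3-benzothiazol-2-yl, with a 3.5-fold lower number from compound 1 to compound 4 (0.55 log units; beyond the scatter); the hetero atoms of that group are therefore not needed to reach the number of compound 1. The earlier phenyl and benzyl compounds did not show this: adding a phenyl to the aromatic carbon of the phenyl compound gives an at least 7.1-fold lower number from compound 2 to compound 4 (0.85 log units; beyond the scatter), and 4-phenylphenyl in place of benzyl gives an at least 7.1-fold lower number from compound 3 to compound 4 (0.85 log units; beyond the scatter). Both steps are floors, since compound 2 and compound 3 each give only a limit of the assay: the limit of > 20000 nM in this assay, at which 2 of the 4 values shown sit.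

On these data alone, whether the gain depends on the added phenyl itself remains open. The compounds shown do not tell how a pyridine in its place, or a carboxylic acid or an amine on it, would read.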